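Replacing a Methyl with Methylsulfonyloxy on a Shared Core

This account rests on a few compounds, and the source may have more. Where it says the series, first, only, none or still open, it means among the compounds named here.

Compound 1 `Nc1ncc(Cc2ccccc2OCc2ccccc2)c(N)n1`: 9120 nM
Compound 2 `Nc1ncc(Cc2ccccc2I)c(N)n1`: 8710 nM
Compound 3 `Cc1ccccc1Cc1cnc(N)nc1N`: 29500 nM

In an assay for inhibition of Dihydrofolate reductase (Gallus gallus) (on this read-out higher numbers stand for weaker inhibition and lower numbers for stronger inhibition), compound 3 gives the highest number of the three; compound 1 and compound 2 both give lower numbers, each beyond the scatter. Compound 4 `CS(=O)(=O)Oc1ccccc1Cc1cnc(N)nc1N` is compound 3 with (methylsulfonyl)oxy in place of methyl on an aromatic carbon. Among the measured compounds shown here, one measured step bears on this change: a 3.4-fold higher number from compound 2 to compound 3 (0.53 log units; beyond the scatter), so the methyl gives a weaker result than the iodo on that aromatic carbon. Compound 1, carrying a different group on that aromatic carbon, also gives a lower number than compound 3. A group of 5 heavy atoms in place of methyl is therefore expected to lower the number, by about a 3.0-fold lower number from compound 3 to compound 4 (0.47 log units; beyond the scatter). Compound 4 is estimated at 10000 nM, with a range from 4000 nM to 25000 nM.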

Compound 4, inhibition constant: 22900 nM
For compound 4 the middle estimate is 2.3-fold (0.36 log units) below the measured one, within the range that was stated.
By their numbers in this assay, from the lowest: compounds 2 and 1 (each within the scatter of the next); then compounds 4 and 3 (each within the scatter of the next).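

In this assay the swap gives a 1.3-fold lower number from compound 3 to compound 4 (0.11 log units; within the scatter) and so leaves methyl and (methylsulfonyl)oxy indistinguishable on this aromatic carbon. The new group does not reach the other two compounds: there is a 2.6-fold higher number from compound 2 to compound 4 (0.42 log units; beyond the scatter) and also a 2.5-fold higher number from compound 1 to compound 4 (0.40 log units; beyond the scatter) on this read-out. A group of 5 heavy atoms with 3 hydrogen-bond acceptors therefore does not by itself bring the lower numbers seen with iodo or the benzyl on oxygen. No measurement at hand explains this result. As far as these compounds go, whether an amine or a carboxylic acid on this carbon would sit nearer compound 2 or compound 3 remains open.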